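A few compounds are considered here, and "the series" means these few. Any claim that something is new, unique, unknown or untested is made for them only; others in the source may bear on it.

Measured compounds:
compound 1 `CC(C)(C)c1ccc(C(=O)N2CCC3(CC2)C(=O)N(CC(=O)NCCN)CN3c2ccccc2)cc1`: 7000 nM
compound 2 `COC(=O)CCNC(=O)CN1CN(c2ccccc2)C2(CCN(C(=O)c3ccc(C4CCCCC4)cc3)CC2)C1=O`: 12900 nM

In an assay on HEK293 cells for displacement of a labelled ligand from NPC1-like intracellular cholesterol transporter 1 (Homo sapiens) (a lower number here means a stronger inhibitor, a higher number a weaker inhibitor), compound 1 gives 7000 nM, the lower of the two numbers. Compound 2 gives 12900 nM; the gap to compound 1 lies within the scatter, so no order between them can be read.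

Compound 3 `CC(C)(C)c1ccc(C(=O)N2CCC3(CC2)C(=O)N(CC(=O)N2CCCC(O)C2)CN3c2ccccc2)cc1` is not yet measured. It differs from compound 1 in one place: 3-hydroxypiperidin-1-yl in place of (2-aminoethyl)amino on a carbonyl carbon. For the measured compounds named here, no measured pair shows this kind of change, so nothing in the numbers points in either direction; the expectation is a step about the size of the scatter or none, a 1.1-fold lower number from compound 1 to compound 3 (0.03 log units; within the scatter). Compound 3 is therefore estimated at 6500 nM, with a range from 2000 nM to 20000 nM.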

Compound 3, half-maximal inhibitory concentration: 12200 nM
Compound 3: middle estimate off by 1.9-fold (0.27 log units), on the low side, within the range that was stated.
By their numbers in this assay, from the lowest: compounds 1, 3 and 2 (each within the scatter of the next).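

In this assay, 3-hydroxypiperidin-1-yl in place of (2-aminoethyl)amino on a carbonyl carbon gives a 1.7-fold higher number from compound 1 to compound 3 (0.24 log units; within the scatter) and no order can be read between the two. This position therefore takes a six-membered non-aromatic ring in place of an open chain with no step beyond the scatter. No measurement available here explains this result.

Still open, on these data alone, is whether a carboxylic acid, a morpholine or a longer amine chain on the same carbonyl carbon would give a step beyond the scatter. An unsubstituted piperidin-1-yl would separate the ring from its hydroxyl.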